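Methyl in place of fluoro: cytotoxicity outlook for compound 3

This account rests on a few compounds, and the source may have more. Where it says the series, first, only, none or still open, it means among the compounds named here.

Compound 1 `C/C(=N\NC(N)=S)c1sc(C)nc1C` and compound 2 `C/C(=N\Nc1nc(-c2ccc(F)cc2)cs1)c1sc(C)nc1C` share the same core and carry different groups on the hydrazone nitrogen. In a toxicity assay on THP-1 cells (Homo sapiens) for cytotoxicity, read by MTT assay (on this read-out higher numbers stand for weaker inhibition of growth and lower numbers for stronger inhibition of growth), compound 1 reaches only the limit of the assay, > 100 ug/mL. In this assay compound 2 likewise returns only a limit, > 100 ug/mL. Compound 2 thus stands at the limit itself, as the limit of > 100 ug/mL in this assay, at which 2 of the 2 values shown sit, shows; no number separates it from compound 1, and no order between the two can be given. Compound 3 `C/C(=N\Nc1nc(-c2ccc(C)cc2)cs1)c1sc(C)nc1C` is not yet measured. It differs from compound 2 by methyl in place of fluoro on an aromatic carbon. Among the compounds with values here, no step between two measured compounds with numbers at both ends is available here, so the size of this change cannot be read from the series. The expected step is none beyond the scatter, a step that the limit leaves unreadable from compound 2 to compound 3, with compound 3 most likely again sitting at the limit. The estimate for compound 3 in this assay is 120 ug/mL, in a range from 50 ug/mL to 300 ug/mL.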

Compound 3, concentration for 50% growth inhibition: > 100 ug/mL
Compound 3 gave a limit, no number (the forecaster's own chance of this, stated with the estimate: 75%); the middle value lies beyond the limit too.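

Compound 2 and compound 3 both return only limits in this assay, so no step can be read between them: the limit of > 100 ug/mL in this assay, at which 3 of the 3 values shown sit. The compounds shown leave open whether methyl in place of fluoro on an aromatic carbon alters growth inhibition at all in this assay or not.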